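Cytotoxicity of a piperazine series in Vero cells

The source may report more compounds than this note shows. Statements on the series, on what has been measured and on what is new or still open speak of the compounds shown alone.

For the measured compounds named here, compound 2, `CON=C1CCC(N(C)N2CCN(c3nc(=O)c4cc(C(F)(F)F)cc([N+](=O)[O-])c4s3)CC2)CC1`, is one of two compounds so far tested in an ADME assay on Vero cells (Chlorocebus sabaeus) for cytotoxicity, read by MTT assay, with a stated time of 72 h; a lower number here means that less compound is tolerated, a higher number that more compound is tolerated. In this assay compound 2 gives > 64 ug/mL, which is a limit of the assay and not a number. Its neighbour compound 1, `CN(CC1CCCCC1)N1CCN(c2nc(=O)c3cc(C(F)(F)F)cc([N+](=O)[O-])c3s2)CC1`, differs from it in one place, and in this assay compound 1 gives > 64 ug/mL, likewise a limit. The change between them, a step that the two limits leave unreadable from compound 1 to compound 2, therefore cannot be sized. Going by the values given here, compound 2 thus stands at the limit of > 64 ug/mL in this assay, at which 2 of the 2 values shown sit, with no measured step around it that can actually be read.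

Compound 3, `Cc1ccc(CNN2CCN(c3nc(=O)c4cc(C(F)(F)F)cc([N+](=O)[O-])c4s3)CC2)cc1`, is not yet measured. Relative to compound 2 the change is a group of 9 heavy atoms (8 carbon, 1 nitrogen; one six-membered aromatic ring of carbon only) in place of a group of 11 heavy atoms (8 carbon, 2 nitrogen, 1 oxygen; one six-membered non-aromatic ring of carbon only), on an amine nitrogen in a ring. Among the compounds with values here, no readable measured step bears on this change; the only neighbouring pair is unreadable from its two limits. Given (the limit of > 64 ug/mL in this assay, at which 2 of the 2 values shown sit), compound 3 is expected to sit at the same limit, so the step of a number no higher from compound 2 to compound 3 (the limit leaves the size open) is expected to be none beyond the scatter. Compound 3 is estimated at 64 ug/mL, with a range from 32 ug/mL to 128 ug/mL.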

Compound 3, half-maximal cytotoxic concentration: > 64 ug/mL
Compound 3: no number, only a limit (the forecaster's own chance of this, stated with the estimate: 70%); the middle value lies on the limit itself.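

In this assay compound 3 gives > 64 ug/mL, which is a limit of the assay and not a number. The steps to compound 3 from compound 1 and from compound 2 cannot be read, and all three compounds stand together: the limit of > 64 ug/mL in this assay, at which 3 of the 3 values shown sit. The compounds shown leave open how far each lies from that limit, and whether any of these changes shifts the tolerated concentration at all.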